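The compounds below may be only part of what the source reports. "The series", "measured", "known", "first", "only" and "open" are said of these compounds alone.

Working notes on the series. All three measured compounds share one core and differ only in the group on the nitrogen on the aromatic ring. Compound 1 `COc1cccc(-c2csc(N/N=C/c3ccco3)n2)c1` gives 343 nM in an assay on isolated protein for inhibition of Amine oxidase [flavin-containing] A (Homo sapiens), read by fluorescence; a higher number here means a weaker inhibitor, a lower number a stronger inhibitor. Going by the values given here, compound 2 `COc1cccc(-c2csc(NN=C(C)C)n2)c1` gives 4430 nM in this assay, the highest of the three numbers measured so far. Compound 3 `COc1cccc(-c2csc(N/N=C3\CCC(C)C3)n2)c1` gives 1450 nM in this assay. Among the compounds with values here, the measured steps are a 13-fold higher number from compound 1 to compound 2 (1.11 log units; beyond the scatter), a 4.2-fold higher number from compound 1 to compound 3 (0.63 log units; beyond the scatter) and a 3.1-fold lower number from compound 2 to compound 3 (0.49 log units; beyond the scatter); in each of them the group with more heavy atoms carries the lower number, with no compound going against this among the three.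

Compound 4 `CCCCCC/C(C)=N/Nc1nc(-c2cccc(OC)c2)cs1` differs from compound 2 by pentyl in place of hydrogen on a saturated chain carbon bound to a carbon with a double bond to nitrogen. Within the data shown here, no measured step exchanges hydrogen for a chain at this place; the nearest analogy is a 3.1-fold lower number from compound 2 to compound 3 (0.49 log units; beyond the scatter), which also enlarges the group on compound 2, though by a ring rather than a chain, so it is only a loose guide. The step from compound 2 to compound 4 in this assay is therefore expected to be a modest lowering, a 2.2-fold lower number from compound 2 to compound 4 (0.35 log units; beyond the scatter). For compound 4 the expected value in this assay is 2000 nM, within a range of 700 nM to 6000 nM.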

Compound 4, half-maximal inhibitory concentration: 1380 nM
Beside the measured number, compound 4's estimate is 1.4-fold (0.16 log units) above it; the range from low to high includes it.
By their numbers in this assay, from the lowest: compound 1; then compounds 4 and 3 (each within the scatter of the next); then compound 2.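

The step to compound 4 shows that this carbon tolerates an open saturated chain: pentyl in place of hydrogen gives a 3.2-fold lower number from compound 2 to compound 4 (0.51 log units; beyond the scatter) in this assay. Until now, the only enlargements that lowered the number from compound 2 were groups containing a ring, so a ring is not required for a lowering beyond the scatter. Going by these compounds alone, compound 4 also fits the pattern among the compounds so far, with the group of more heavy atoms carrying the lower number, and nothing on hand explains the change.

With pentyl the only chain shown at this place, it remains open whether ethyl or a longer chain such as octyl would lower the number further or less. Also open, as far as these compounds go, is how an amine or a carboxylic acid would read on this carbon.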